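Sulfamoyl in Place of Hydroxy on Two Related Cores

The source may hold more compounds than are shown below. What is called first, only, known or untested is meant among the compounds shown, and "the series" means these compounds.

Compound 1: `Oc1ccc(Nc2ncnc3ccc(NC(=S)NCc4ccccc4)cc23)cc1` — in a functional assay on MDA-MB-231 cells (Homo sapiens) for inhibition, read by MTT assay, with a stated time of 48 h (on this read-out lower numbers stand for stronger inhibition of growth and higher numbers for weaker inhibition of growth), compound 1 gives 27000 nM
Compound 2: `NS(=O)(=O)c1ccc(Nc2ncnc3ccc(NC(=S)NCc4ccccc4)cc23)cc1` — compound 2 gives only a limit in this assay, > 30000 nM
Compound 3: `Oc1ccc(NC(=S)Nc2ccc3ncnc(Nc4cccc(Br)c4)c3c2)cc1` — compound 3 gives 17300 nM in this assay

The change from compound 1 to compound 2 is sulfamoyl in place of hydroxy on an aromatic carbon. The measured step is an at least 1.1-fold higher number from compound 1 to compound 2 (0.04 log units; that floor lies within the scatter); compound 2 sits at the limit of the assay, (the limit of > 30000 nM in this assay, at which 1 of the 3 values shown sits), so the true size of that step is not known. Compound 3 rests on a different core; the difference between the core of compound 1 and the core of compound 3 is not broken down here. Compound 3 and compound 1 lie within the scatter of each other in this assay.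

Compound 4 `NS(=O)(=O)c1ccc(NC(=S)Nc2ccc3ncnc(Nc4cccc(Br)c4)c3c2)cc1` has not yet been measured. It differs from compound 3 by sulfamoyl in place of hydroxy on an aromatic carbon, the same change made between compound 1 and compound 2, at a place described in the same words. The expected step is a 1.7-fold higher number from compound 3 to compound 4 (0.24 log units; within the scatter), resting on the step of an at least 1.1-fold higher number from compound 1 to compound 2 (0.04 log units; that floor lies within the scatter) seen with compound 2. Compound 4 is therefore expected to give about 30000 nM in this assay. The estimated range for compound 4 runs from 14000 nM to 65000 nM, with a real chance that only a limit is reported.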

Compound 4, concentration for 50% growth inhibition: > 30000 nM
Compound 4 gave a limit, no number; the forecaster's own chance of this, stated with the estimate: 50%; the middle value lies on the limit itself.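

In this assay, the change carried over to the second core gives an at least 1.7-fold higher number from compound 3 to compound 4 (0.23 log units; that floor lies within the scatter), and that figure is a floor rather than a measured size. Set beside the first core, the two steps show no disagreement, but they do not establish that the change has the same size on both cores: the same change on two cores in this assay, an at least 1.1-fold higher number (0.04 log units; that floor lies within the scatter) from compound 1 to compound 2 and an at least 1.7-fold higher number (0.23 log units; that floor lies within the scatter) from compound 3 to compound 4; the limit leaves it open whether they differ The result shows only that neither sulfamoyl compound gave a number on its core, and it does not show how far growth inhibition shifts with this change on either core: the limit of > 30000 nM in this assay, at which 2 of the 4 values shown sit.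

The compounds shown leave open how a carboxylic acid or an amine would read in place of the hydroxy on either core. Going by these compounds, it also remains open whether a smaller sulfur group, such as methylsulfonyl, would return a number in this assay rather than a limit.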